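The compounds below may be only part of what the source reports. "The series", "measured", "known", "first", "only" and "open" are said of these compounds alone.

Measured in a functional assay on MIA PaCa-2 cells (Homo sapiens) for inhibition, read by MTT assay, with a stated time of 3 days; on this read-out lower numbers stand for stronger inhibition and higher numbers for weaker inhibition:

- Compound 1 `CC(C)S(=O)(=O)c1ccc(S(=O)(=O)N2CCC[C@@H](C(=O)N3CCC(F)(F)CC3)C2)cc1`: > 3000 nM, a limit
- Compound 2 `CCN(CC)S(=O)(=O)c1ccc(S(=O)(=O)N2CCC[C@@H](C(=O)N3CCOCC3)C2)cc1`: > 10000 nM, a limit

Neither compound has a measured number in this assay. Compound 2 stands at > 10000 nM, which is a limit of the assay and not a number. Compound 3 `CCN(CC)S(=O)(=O)c1ccc(S(=O)(=O)N2CCC[C@@H](C(=O)N[C@H]3CC[C@@H](OC)CC3)C2)cc1` keeps the core of compound 2 and differs from it in one place, ((4-methoxycyclohexyl)amino in place of morpholin-4-yl on a carbonyl carbon). In words, (4-methoxycyclohexyl)amino stands in place of morpholin-4-yl on a carbonyl carbon.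

Among the measured compounds shown here, no measured pair in this small set shows the effect of such an exchange, so the expectation rests on the two limits alone. The expected change is an at least 1.2-fold lower number from compound 2 to compound 3 (0.09 log units; that floor lies within the scatter), which is estimated to stay within the usual scatter. For compound 3 the estimated value is 8000 nM, with an expected range from 2000 nM to 30000 nM.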

Compound 3, half-maximal inhibitory concentration: > 10000 nM
Compound 3 ended at the assay's limit; the forecaster's own chance of this, stated with the estimate: 65%; middle value at least 1.2-fold (0.09 log units) away from the limit.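

In this assay compound 3 gives > 10000 nM, a limit and not a number. Among the compounds shown here, compound 2 gives > 10000 nM, also a limit, so no step from compound 2 to compound 3 can be read. The compounds shown leave open what the exchange of morpholin-4-yl for (4-methoxycyclohexyl)amino does to inhibition.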